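The source may hold more compounds than are shown below. What is called first, only, known or untested is meant among the compounds shown, and "the series" means these compounds.

Measured compounds:
- compound 1, `Cc1n[nH]c2ccc(-c3nc4cnc(N5CCN(C)CC5)cn4c3Nc3ccc(F)cc3)cc12`, with 0% in a functional assay on MV4-11 cells (Homo sapiens) for inhibition, with a stated time of 120 h, tested at 10 uM; a lower number here means less inhibition, a higher number more inhibition at the concentration tested (going by the name of the read-out)
- compound 2, `Cc1n[nH]c2ccc(-c3nc4cnc(N5CCN(C)CC5)cn4c3Nc3cccc(Cl)c3)cc12`, with 0% in this assay
- compound 3, `Cc1n[nH]c2ccc(-c3nc4cnc(N5CCN(C)CC5)cn4c3Nc3ccc(F)cc3Br)cc12`, with 82.4% in this assay

Compound 3 stands highest of the three numbers in this assay, and both of its neighbours lie beyond the scatter: a number 82.4 percentage points higher from compound 1 to compound 3 (beyond the scatter) and a number 82.4 percentage points higher from compound 2 to compound 3 (beyond the scatter). The two compounds without bromine sit together, as no change at the digits printed from compound 1 to compound 2 (within the scatter) shows.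

Compound 4, `COc1ccc(Nc2c(-c3ccc4[nH]nc(C)c4c3)nc3cnc(N4CCN(C)CC4)cn23)cc1OC`, is not yet measured. It differs from compound 3 in one place: 3,4-dimethoxyphenyl in place of 2-bromo-4-fluorophenyl on a nitrogen on an aromatic ring. Among the measured compounds shown here, the bromine-bearing group is the only feature that separates compound 3 from compounds 1 and 2, and swapping one aryl group for another without bromine moved nothing in no change at the digits printed from compound 1 to compound 2 (within the scatter). Both steps that introduced the 2-bromo-4-fluorophenyl group were large, so taking it away is expected to reverse most of that gain in this assay.

On that basis compound 4 is expected to give about 10%, within a range of 0% to 45%, an estimated step of a number 72.4 percentage points lower from compound 3 to compound 4 (beyond the scatter).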

Compound 4, a percentage reported as inhibition, at one concentration (the size of the read-out at that concentration, not a potency): 6.27%
Estimate against measurement, compound 4: 3.7 percentage points above; the measured number falls inside the stated range.
By their numbers in this assay, from the lowest: compounds 1, 2 and 4 (each within the scatter of the next); then compound 3.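

The change to 3,4-dimethoxyphenyl on this nitrogen gives a number 76.1 percentage points lower from compound 3 to compound 4 (beyond the scatter) in this assay, so a third aryl group without bromine, and the first here bearing oxygen, also fails to keep the inhibition seen with 2-bromo-4-fluorophenyl. It joins the other two bromine-free compounds, with a number 6.3 percentage points higher from compound 2 to compound 4 (within the scatter) and a number 6.3 percentage points higher from compound 1 to compound 4 (within the scatter), which leaves the 2-bromo-4-fluorophenyl group as the only one of the four on this nitrogen tied to a high number, with no compound shown going against that. Nothing available explains why this group stands apart.

The compounds shown leave open whether bromine alone carries the effect or needs the fluorine as well. A 2-bromophenyl or a 2-chloro-4-fluorophenyl group in this place would separate those two readings.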